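Moving a methoxy group around the styryl ring

A few compounds are considered here, and "the series" means these few. Any claim that something is new, unique, unknown or untested is made for them only; others in the source may bear on it.

Measured compounds:
compound 1 `COc1ccc(/C=C/C[C@H]2C[C@@H]([C@@H](O)c3ccccc3)CO[C@@H]2c2ccccc2)cc1` — 8300 nM
compound 2 `COc1ccc([C@H]2OC[C@H]([C@@H](O)c3ccc(OC)c(OC)c3)C[C@@H]2C/C=C/c2ccc(OC)c(OC)c2)cc1` — 46700 nM

In a functional assay on HeLa cells (Homo sapiens) for cytotoxicity, read by WST assay, with a stated time of 48 h (a higher number here means a weaker inhibitor, a lower number a stronger inhibitor), compound 1 gives 8300 nM, the lower of the two numbers seen so far, so it is the stronger of the pair. In this assay compound 2 gives 46700 nM, a higher number, and the gap between the two lies beyond the usual scatter.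

Compound 3 `COc1cccc(/C=C/C[C@H]2C[C@@H]([C@@H](O)c3ccccc3)CO[C@@H]2c2ccccc2)c1` has not been measured in this assay. It differs from compound 1 only in one place: 3-methoxyphenyl in place of 4-methoxyphenyl on a double-bonded chain carbon bound to a double-bonded chain carbon

Going by the values given here, no pair of measured compounds shows a step of this kind, so there is no measured change to lean on. The expectation is a small step, a 1.2-fold higher number from compound 1 to compound 3 (0.08 log units; within the scatter), that stays within the scatter of repeated measurements. On that basis compound 3 is estimated to give 10000 nM in this assay, with a range from 3000 nM to 33000 nM.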

Compound 3, half-maximal inhibitory concentration: 10900 nM
Compound 3: middle estimate off by 1.1-fold (0.04 log units), on the low side; low and high end bracket the measured number.
By their numbers in this assay, from the lowest: compounds 1 and 3 (each within the scatter of the next); then compound 2.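

In this assay, 3-methoxyphenyl in place of 4-methoxyphenyl on a double-bonded chain carbon bound to a double-bonded chain carbon gives a 1.3-fold higher number from compound 1 to compound 3 (0.12 log units; within the scatter), so this swap leaves compound 1 and compound 3 indistinguishable. Going by these compounds alone, compound 1 and compound 2 differ in more than one place, so they could not isolate this change; this pair is the first to do so, and it shows that this one rearrangement of the same atoms produces no measurable change in this assay. Nothing measured here offers an explanation for this result.

From the compounds shown here alone, it remains open whether the methoxy group itself matters at this place. An amine or a carboxylic acid on the ring in its stead, or a longer chain on the oxygen, could still move the number beyond the scatter.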